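This account rests on a few compounds, and the source may have more. Where it says the series, first, only, none or still open, it means among the compounds named here.

In a functional assay on MCF7 cells (Homo sapiens) for cytotoxicity, read by WST assay, with a stated time of 72 h (on this read-out higher numbers stand for weaker inhibition and lower numbers for stronger inhibition), compound 1 `Cc1ccc(C2(c3ccc(O)cc3)C(=O)Nc3c2ccc(F)c3F)cc1` stands at 1.7 nM, the only number shown for it, with one further entry that gives no single number. Compound 2 `COc1ccc(C2(c3ccc(O)cc3)C(=O)Nc3c2ccc(F)c3F)cc1` gives 2.1 nM; 6.3 nM; > 1000 nM (3 entries). Compound 3 `CCCCCOc1ccc(C2(c3ccc(O)cc3)C(=O)Nc3c2ccc(F)c3F)cc1` differs from compound 1 by pentyloxy in place of methyl on an aromatic carbon. Among the compounds with values here, no measured step covers this change, so the size of the shift in this assay remains uncertain. A moderate weakening is expected, an estimated 5.9-fold higher number from compound 1 to compound 3 (0.77 log units; beyond the scatter). The estimate for compound 3 is 10 nM, with an expected range of 1.5 nM to 100 nM.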

Compound 3, half-maximal inhibitory concentration: > 1000 nM
Compound 3: no number, only a limit; the forecaster's own chance of this, stated with the estimate: 10%; middle value at least 100-fold (2.00 log units) from the limit.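

In this assay, the position para to a large group does not accept every replacement of methyl: pentyloxy gives an at least 580-fold higher number from compound 1 to compound 3 (2.76 log units; beyond the scatter). For compound 3, the value > 1000 nM is a limit and not a number. The size of this step needs caution, because compound 2 reaches the same limit in only one of its entries: the several entries of compound 2 in this assay, 2.1 nM; 6.3 nM; > 1000 nM (3 entries)

Open, on these data alone, is how ethoxy, butoxy or an amine would read at this position. Also open, as far as these compounds go, is where between methyl and pentyloxy the large loss sets in.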